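The source may report more compounds than this note shows. Statements on the series, on what has been measured and on what is new or still open speak of the compounds shown alone.

Measured compounds:
compound 1 `O=C1Nc2ccccc2C1(c1ccc(O)cc1)c1ccc(F)cc1` – 28 nM
compound 2 `O=C1Nc2ccccc2C1(c1ccc(O)cc1)C1CCCCCC1` – 247 nM
compound 3 `Cc1cc(C)c2c(c1)C(c1ccc(O)cc1)(c1ccc(F)cc1)C(=O)N2` – 40 nM

All three values come from a functional assay on MCF7 cells (Homo sapiens) for cytotoxicity, read by WST assay, with a stated time of 72 h; a lower number here means a stronger inhibitor, a higher number a weaker inhibitor. Compound 1 and compound 3 share one kind of substitution pattern on the saturated ring carbon but differ in their cores; the difference between the two cores is not broken down here. What the values show is that compound 3 and compound 1 lie within the scatter of each other in this assay, so no order between them is claimed.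

Within the data shown here, the one counted step is the change from compound 1 to compound 2, (cycloheptyl in place of 4-fluorophenyl on a saturated ring carbon), which gave an 8.8-fold higher number from compound 1 to compound 2 (0.95 log units; beyond the scatter). Compound 4 `Cc1cc(C)c2c(c1)C(c1ccc(O)cc1)(C1CCCCCC1)C(=O)N2` is unmeasured in this assay; it comes from compound 3 by cycloheptyl in place of 4-fluorophenyl on a saturated ring carbon. The two "place" descriptions are the same word for word, so this is the same change applied to the other core.

The expectation for compound 4 rests on a single earlier occurrence of this change, and a weakening of a similar size is expected: an 8.8-fold higher number from compound 3 to compound 4 (0.94 log units; beyond the scatter), set beside an 8.8-fold higher number from compound 1 to compound 2 (0.95 log units; beyond the scatter). Because compound 3 gives 40 nM, compound 4 is expected to come out near 350 nM, with a plausible range from 150 nM to 800 nM; whether the second core carries the change equally cannot be checked from one prior example.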

Compound 4, half-maximal inhibitory concentration: > 1000 nM
Compound 4: a limit, no number; the forecaster's own chance of this, stated with the estimate: 5%; middle value at least 2.8-fold (0.45 log units) away from the limit.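

In this assay compound 4 gives > 1000 nM, which is a limit of the assay and not a number: the limit of > 1000 nM in this assay, at which 1 of the 4 values shown sits.

Cycloheptyl in place of 4-fluorophenyl on the saturated ring carbon gives an at least 25-fold higher number from compound 3 to compound 4 (1.39 log units; beyond the scatter), so the change weakens on the core of compound 3 as it does on the core of compound 1, but the size of the step does not carry over: the same change on two cores in this assay, an 8.8-fold higher number (0.95 log units; beyond the scatter) from compound 1 to compound 2 and an at least 25-fold higher number (1.39 log units; beyond the scatter) from compound 3 to compound 4, at least 2.8-fold (0.45 log units) apart, beyond the scatter of two such steps

This shows that, for these two pairs, the direction of the change held from one core to the other while its size did not; it does not show the full size of the step on the core of compound 3, whose upper end the limit leaves open, nor does it show why the two cores differ, and two pairs set no rule for any further core.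

The compounds shown leave open whether a smaller ring such as cyclopentyl or cyclohexyl, or an open chain such as n-butyl, in the same place would track 4-fluorophenyl or cycloheptyl on either core. They also leave open whether plain phenyl in that place would give the same result on both cores.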